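From Methoxy to Fluoro on the Shared Core

The source may report more compounds than this note shows. Statements on the series, on what has been measured and on what is new or still open speak of the compounds shown alone.

Measured so far in a functional assay on SN12C cells (Homo sapiens) for inhibition, read by sulforhodamine B assay, with a stated time of 48 h; on this read-out higher numbers stand for weaker inhibition of growth and lower numbers for stronger inhibition of growth:
Compound 1, `Nc1cc(N)c2nc(-c3ccccc3)c(Oc3ccc(Cl)c(Cl)c3)nc2c1`, reaches only a limit of this assay: < 100000 nM.
Compound 2, `COc1ccc(Sc2nc3cc(N)cc(N)c3nc2-c2ccccc2)cc1`, gives 24000 nM.

Compound 2 thus holds the only real number shown; the other value is a limit. Compound 3, `Nc1cc(N)c2nc(-c3ccccc3)c(Sc3ccc(F)cc3)nc2c1`, differs from it by fluoro in place of methoxy on an aromatic carbon. Within the data shown here, the single measured step, a step that the limit leaves unreadable from compound 1 to compound 2, cannot be sized because of the limit of < 100000 nM in this assay, at which 1 of the 2 values shown sits, so no measured step bears on the methoxy-to-fluoro change. With nothing to point either way, compound 3 is expected to stay within the usual scatter of compound 2, a step of no change at the digits printed from compound 2 to compound 3 (within the scatter). The estimate for compound 3 is 24000 nM, within a wide range of 6000 nM to 90000 nM.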

Compound 3, concentration for total growth inhibition: < 100000 nM
Compound 3 was reported as a limit; the forecaster's own chance of this, stated with the estimate: 15%; the middle value does not contradict the limit.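

Compound 3 also gives only a limit, so its steps from compound 1 and compound 2 cannot be read: the limit of < 100000 nM in this assay, at which 2 of the 3 values shown sit. On these data alone, how fluoro compares with methoxy in this assay stays open.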